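The compounds below may be only part of what the source reports. "The series", "measured", "known", "first", "only" and "open" are said of these compounds alone.

The measured compounds, each with its read-out in a functional assay on 3T3-L1 cells (Mus musculus) for inhibition, with a stated time of 20 min, tested at 20 uM; a higher number here means more inhibition at the concentration tested (going by the name of the read-out), a lower number less inhibition:
compound 1, `Cc1ccc(S(=O)(=O)n2cc(CN(Cc3cn(Cc4ccccc4)nn3)S(=O)(=O)c3ccccc3)c3ccccc32)cc1`, gives -18%;
compound 2, `Cc1ccc(S(=O)(=O)N(Cc2cn(Cc3ccccc3Cl)nn2)Cc2cn(S(=O)(=O)c3ccc(C)cc3)c3ccccc23)cc1`, gives -4.8%;
compound 3, `Fc1cccc(CNCc2c[nH]c3ccccc23)c1F`, gives -1.7%.

Compound 2 stands second highest of these three numbers. Its nearest neighbour is compound 3, whose number lies a little higher but within the scatter of repeated measurements, so no order between the two can be read. The furthest is compound 1, whose number lies lower by a gap beyond the scatter. None of the three shows inhibition at the concentration tested; all sit at or under zero.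

Compound 4, `COc1ccc(Cn2cc(CN(Cc3cn(S(=O)(=O)c4ccc(C)cc4)c4ccccc34)S(=O)(=O)c3ccc(C)cc3)nn2)cc1`, has not yet been measured. It differs from compound 2 by one change: 4-methoxyphenyl in place of 2-chlorophenyl on a saturated chain carbon bound to an aromatic nitrogen. Going by the values given here, no measured pair shows the effect of such a change here, so there is nothing to lean on beyond the fact that compound 2 and compound 3 already sit close to zero. The step from compound 2 to compound 4 is expected to be a number 0.2 percentage points lower from compound 2 to compound 4 (within the scatter), that is, none beyond the scatter in either direction. Compound 4 is therefore estimated at -5%, with a range from -20% to 10%.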

Compound 4, a percentage reported as inhibition, at one concentration (the size of the read-out at that concentration, not a potency): 1%
Beside the measured number, compound 4's estimate is 6 percentage points below it; measured number inside the range.
By their numbers in this assay, from the lowest: compound 1; then compounds 2, 3 and 4 (each within the scatter of the next).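

In this assay, going by these compounds alone, the exchange of 2-chlorobenzyl for 4-methoxybenzyl gives the first direct reading at this place, on a saturated chain carbon bound to an aromatic nitrogen, with a number 5.8 percentage points higher from compound 2 to compound 4 (within the scatter) as its result. The new group brings one hydrogen-bond acceptor where the old one had none, yet the two compounds cannot be told apart, and compound 4 at 1% stays close to zero, so this single change produces no clear inhibition. No measurement bears on why the read-out stays where it does.

The compounds shown leave open whether an amine or a carboxylic acid in place of the 4-methoxyphenyl would move the read-out beyond the scatter. Within the data shown here, no pair here separates the change of substituent from the change of its place on the ring.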